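The source may hold more compounds than are shown below. What is called first, only, known or untested is meant among the compounds shown, and "the series" means these compounds.

Measured compounds in this series:

- compound 1, `COc1cc2c(Nc3cccc(C#N)c3)ncnc2cc1OCCCN1CCCCC1`: 29100 nM
- compound 2, `COc1cc2c(Nc3cccc(C#N)c3)ncnc2cc1OCCCN1CCC(C)CC1`: 17700 nM
- compound 3, `COc1cc2c(Nc3ccccc3C#N)ncnc2cc1OCCCN1CCCCC1`: 15300 nM

All three values come from a functional assay on DU-145 cells (Homo sapiens) for antiproliferative activity, read by MTT assay, with a stated time of 72 h; on this read-out higher numbers stand for weaker inhibition and lower numbers for stronger inhibition. The three numbers sit close together, and none of the steps between them reaches beyond the usual scatter of the measurement.

Two single changes connect the measured compounds. From compound 1 to compound 2 the change is methyl in place of hydrogen on a saturated ring carbon, and on this assay it gave a 1.6-fold lower number from compound 1 to compound 2 (0.22 log units; within the scatter). From compound 1 to compound 3 the change is 2-cyanophenyl in place of 3-cyanophenyl on a nitrogen on an aromatic ring, a rearrangement of the same atoms, and it gave a 1.9-fold lower number from compound 1 to compound 3 (0.28 log units; within the scatter).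

Compound 4, `COc1cc2c(Nc3ccccc3C#N)ncnc2cc1OCCCN1CCC(C)CC1`, has not yet been measured. It differs from compound 3 by methyl in place of hydrogen on a saturated ring carbon. This is the same change already made from compound 1 to compound 2: the group that leaves, the group that enters and the place are the same word for word. The cores differ as described by 2-cyanophenyl in place of 3-cyanophenyl on a nitrogen on an aromatic ring.

For the measured compounds named here, for compound 4 the step in this assay is expected to be a 1.5-fold lower number from compound 3 to compound 4 (0.18 log units; within the scatter), because the one earlier instance of this change gave a 1.6-fold lower number from compound 1 to compound 2 (0.22 log units; within the scatter) and that is the only precedent available here. Going by the values given here, with only one prior example, both a step of that size and no step at all would be consistent with what has been seen.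

On that basis compound 4 is estimated at 10000 nM in this assay, with an expected range from 5000 nM to 22000 nM.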

Compound 4, half-maximal inhibitory concentration: 11900 nM
Estimate against measurement, compound 4: 1.2-fold (0.08 log units) below; measured number inside the range.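

In this assay, methyl in place of hydrogen on the saturated ring carbon gives a 1.3-fold lower number from compound 3 to compound 4 (0.11 log units; within the scatter), and this step on the second core agrees with the earlier one: the same change on two cores in this assay, a 1.6-fold lower number (0.22 log units; within the scatter) from compound 1 to compound 2 and a 1.3-fold lower number (0.11 log units; within the scatter) from compound 3 to compound 4, 1.3-fold (0.11 log units) apart, within the scatter of two such steps. The change from 3-cyanophenyl to 2-cyanophenyl, read with 4-methylpiperidin-1-yl in place of piperidin-1-yl, gives a 1.5-fold lower number from compound 2 to compound 4 (0.17 log units; within the scatter), and it also agrees with its earlier instance: the same change on two cores in this assay, a 1.9-fold lower number (0.28 log units; within the scatter) from compound 1 to compound 3 and a 1.5-fold lower number (0.17 log units; within the scatter) from compound 2 to compound 4, 1.3-fold (0.11 log units) apart, within the scatter of two such steps. Both changes therefore carry from one core to the other without a detectable difference in step size, but each of the four steps lies within the scatter, so the series does not show that either change has a real effect, and agreement between two small steps on two cores is only a weak test of additivity.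

The compounds shown leave open whether any change at this site of the saturated ring would give a step beyond the scatter, for example an amine, a carboxylic acid or a longer chain in place of the methyl. They also leave open whether the agreement between steps would hold for a larger step, or on a core carrying something other than a nitrile on the phenyl ring.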